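Compound 3 and the limits of its neighbours

A few compounds are considered here, and "the series" means these few. Any claim that something is new, unique, unknown or untested is made for them only; others in the source may bear on it.

Measured in an ADME assay on Huh7.5.1 cells (Homo sapiens) for cytotoxicity, read by WST assay, with a stated time of 48 h; on this read-out lower numbers stand for higher toxicity in this test and higher numbers for lower toxicity in this test:
Compound 1 `Cc1c(-c2ccc(Cc3ccc(C(O)C(F)(F)F)cc3)cc2)[nH]c2cccc(F)c2c1=O`: > 10000 nM
Compound 2 `Cc1c(-c2ccc(Cc3ccc(S(=O)(=O)C(F)(F)F)cc3)cc2)[nH]c2cccc(F)c2c1=O`: > 2500 nM

For compound 2, > 2500 nM is a limit, not a number. For compound 1, > 10000 nM is also a limit. Compound 3 `Cc1c(-c2ccc(Cc3ccc(S(=N)(=O)C(F)(F)F)cc3)cc2)[nH]c2cccc(F)c2c1=O` differs from compound 2 by a group of 7 heavy atoms (1 carbon, 1 nitrogen, 1 oxygen, 3 fluorine, 1 sulfur; no ring) in place of a group of 7 heavy atoms (1 carbon, 2 oxygen, 3 fluorine, 1 sulfur; no ring), on an aromatic carbon, para to a large group. Among the measured compounds shown here, the only measured step that bears on this change is a step that the two limits leave unreadable from compound 1 to compound 2, so it offers no size to carry over. No step beyond the usual scatter is therefore expected in this assay, and no direction can be expected. The expected step is a step that the limit leaves unreadable from compound 2 to compound 3. For compound 3 the estimated value is 5000 nM, with an expected range of 2500 nM to 15000 nM.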

Compound 3, half-maximal cytotoxic concentration: > 10000 nM
Compound 3: a limit, no number (the forecaster's own chance of this, stated with the estimate: 75%); middle value at least 2.0-fold (0.30 log units) away from the limit.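

In this assay compound 3 gives > 10000 nM, which is a limit and not a number. No step can be read among compound 1, compound 2 and compound 3. The compounds shown leave open whether these three differ in cytotoxicity at all.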